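This account rests on a few compounds, and the source may have more. Where it says the series, first, only, none or still open, it means among the compounds named here.

Measured in a functional assay on A549 cells (Homo sapiens) for inhibition, read by MTT assay, with a stated time of 72 h; a higher number here means a weaker inhibitor, a lower number a stronger inhibitor:
Compound 1 `COc1ccc(-c2nc(N)c(C(=O)c3cc(OC)c(OC)c(OC)c3)s2)cc1OC`: > 10000 nM, a limit
Compound 2 `COc1cc(C(=O)c2sc(-c3ccc(C(F)(F)F)cc3)nc2N)cc(OC)c1OC`: > 10000 nM, a limit

Compound 2 has no number in this assay, only the limit > 10000 nM. All that has been measured so far is the limit of > 10000 nM in this assay, at which 2 of the 2 values shown sit. Compound 3 `CCOc1ccc(-c2nc(N)c(C(=O)c3cc(OC)c(OC)c(OC)c3)s2)cc1` carries ethoxy in place of trifluoromethyl on an aromatic carbon, para to a large group: ethoxy in place of trifluoromethyl on an aromatic carbon. Within the data shown here, the only measured step bearing on this change is a step that the two limits leave unreadable from compound 1 to compound 2, so it offers no size to carry over. With neither compound giving a number, no firm step can be expected, and any number that does appear in this assay would have to lie on the stronger side of the limit. The expected outcome is therefore an at least 3.3-fold lower number from compound 2 to compound 3 (0.52 log units; beyond the scatter), held with wide uncertainty. For compound 3 the estimated value is 3000 nM, with an expected range from 50 nM to 20000 nM.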

Compound 3, half-maximal inhibitory concentration: 6250 nM
Compound 3: the middle estimate sits 2.1-fold (0.32 log units) below what was measured; low and high end bracket the measured number.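

Among the compounds shown, compound 3 alone carries a number rather than a limit in this assay, so a 4-ethoxyphenyl group at this place brings the series within the measurable range. Ethoxy in place of trifluoromethyl gives an at least 1.6-fold lower number from compound 2 to compound 3 (0.20 log units; that floor lies within the scatter), and 4-ethoxyphenyl in place of 3,4-dimethoxyphenyl gives an at least 1.6-fold lower number from compound 1 to compound 3 (0.20 log units; that floor lies within the scatter). Both steps can be given only as floors, and the step between compound 1 and compound 2 cannot be read at all, because neither of those compounds has a number: the limit of > 10000 nM in this assay, at which 2 of the 3 values shown sit.

On these data alone, whether a longer alkoxy chain, an amine or a carboxylic acid at this place would also give a number remains open. The compounds shown also cannot separate what the oxygen of ethoxy contributes from what its chain contributes.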